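A few compounds are considered here, and "the series" means these few. Any claim that something is new, unique, unknown or untested is made for them only; others in the source may bear on it.

Working notes on the series.

Compound 1 `N#Cc1c(-c2ccc(Cl)cc2)nc(SCC(=O)Nn2c(COc3ccc(Cl)cc3Cl)nc3ccccc3c2=O)n(Cc2ccccc2)c1=O` and compound 2 `N#Cc1c(-c2ccc(O)cc2)nc(SCC(=O)Nn2c(COc3ccc(Cl)cc3Cl)nc3ccccc3c2=O)n(Cc2ccccc2)c1=O` share one core; compound 3 `N#Cc1c(Nc2ccc(Cl)cc2)nc(SCC(=O)Nn2c(COc3ccc(Cl)cc3Cl)nc3ccccc3c2=O)nc1-c1ccccc1` and the unmeasured compound 4 `N#Cc1c(Nc2ccc(O)cc2)nc(SCC(=O)Nn2c(COc3ccc(Cl)cc3Cl)nc3ccccc3c2=O)nc1-c1ccccc1` share another. The difference between the two cores is not broken down here. In a functional assay on the whole organism (strain albino) for inhibition, with Rattus norvegicus as the target, read by paw edema, with stated times of 1 h and 0.5 h, at a dose of 100 mg/kg by the oral route (on this read-out lower numbers stand for less inhibition and higher numbers for more inhibition at the one dose given (going by the name of the read-out)), compound 1 gives 61.5%. Compound 2 gives 51.9% in this assay. Compound 3 gives 51.9% in this assay, level with compound 2 at the digits printed, and these two stand together as the lowest of the three numbers; the gap to compound 1 lies within the scatter, so no order is claimed among the three.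

The change from compound 1 to compound 2 is hydroxy in place of chloro on an aromatic carbon. Its effect in this assay was a number 9.6 percentage points lower from compound 1 to compound 2 (within the scatter), a step within the scatter. The change from compound 3 to compound 4 is hydroxy in place of chloro on an aromatic carbon, the same change at the same kind of place as the one already measured, here made on the second core.

With a single measured instance of this change, and that one within the scatter, the expectation for compound 4 rests only on the step seen from compound 1 to compound 2 carried over onto compound 3. The step in this assay is expected to be about a number 7.9 percentage points lower from compound 3 to compound 4 (within the scatter), a small drop, because the measured precedent is a number 9.6 percentage points lower from compound 1 to compound 2 (within the scatter). Compound 4 is therefore estimated at 44% in this assay. The expected range for compound 4 runs from 30% to 58%.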

Compound 4, a percentage reported as inhibition, in the whole organism at one dose (the size of the read-out at that dose, not a potency): 61.5%
For compound 4 the middle estimate is 17.5 percentage points below the measured one, and the stated range ends below it.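

In this assay, hydroxy in place of chloro on the second core gives a number 9.6 percentage points higher from compound 3 to compound 4 (within the scatter), a step that taken alone cannot be told apart from repeated measurement. Set beside the earlier step, the change does not carry over from one core to the other as a step of fixed size and direction, so the step measured on one core is a poor guide to the step on the other in this series: the same change on two cores in this assay, a number 9.6 percentage points lower (within the scatter) from compound 1 to compound 2 and a number 9.6 percentage points higher (within the scatter) from compound 3 to compound 4, 19.2 percentage points apart, beyond the scatter of two such steps. For the compounds shown here, this shows only that the two steps differ as a pair; neither step alone establishes an effect of the change on its own core, and one pair on each core cannot show which part of the difference between the cores goes with the gap, or whether the gap would hold on repeated measurement.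

The compounds shown leave open how an amine or a methoxy group would read at the same place, on an aromatic carbon para to a large group, on either core. They also leave open whether a further core would follow the step of the first core, that of the second, or neither.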